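The compounds below may be only part of what the source reports. "The series", "measured", "known", "first", "only" and "open" are said of these compounds alone.

In a functional assay on HepG2 cells (Homo sapiens) for antiproliferative activity, read by MTT assay, with a stated time of 48 h (on this read-out lower numbers stand for stronger inhibition and higher numbers for weaker inhibition), the series stands as follows
- compound 1 `CCn1c(C(=O)NCCN)ccc1C(CC)(CC)c1ccc(OCCC(O)(CC)CC)c(C)c1` gives 1590 nM
- compound 2 `C=CCN(C)C(=O)c1ccc(C(CC)(CC)c2ccc(OCCC(O)(CC)CC)c(C)c2)n1CC` gives > 50000 nM (a limit of the assay, not a number)
- compound 3 `CCn1c(C(=O)NC(CO)CCO)ccc1C(CC)(CC)c1ccc(OCCC(O)(CC)CC)c(C)c1` gives 24800 nM

Compound 3 holds the higher of the two numbers that are not limits. Compound 4 `CCn1c(C(=O)NC(C)CO)ccc1C(CC)(CC)c1ccc(OCCC(O)(CC)CC)c(C)c1` follows with hydrogen in place of hydroxymethyl on a saturated chain carbon, two bonds along the chain from an amide-type nitrogen. For the measured compounds named here, no measured step makes this exact change. The two steps reaching compound 3 (first a 16-fold higher number from compound 1 to compound 3 (1.19 log units; beyond the scatter), then an at least 2.0-fold lower number from compound 2 to compound 3 (0.30 log units; that floor lies within the scatter)) replace the whole amide substituent and bear only loosely. Compound 4 lacks the 2-aminoethyl of compound 1 (which gives 1590 nM), so only a small step, not beyond the scatter, is expected in this assay here. The estimated step is a 1.2-fold lower number from compound 3 to compound 4 (0.09 log units; within the scatter) and its direction is uncertain. The expected value for compound 4 is 20000 nM (estimated range 7000 nM to 50000 nM).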

Compound 4, half-maximal inhibitory concentration: 43100 nM
Compound 4: middle estimate off by 2.2-fold (0.33 log units), on the low side, and the stated range covers the measured number.
By their numbers in this assay, from the lowest: compound 1; then compounds 3 and 4 (each within the scatter of the next). At a limit, above all of these: compound 2.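

In this assay, hydrogen in place of hydroxymethyl on a saturated chain carbon, two bonds along the chain from an amide-type nitrogen, carries no readable weight, with a 1.7-fold higher number from compound 3 to compound 4 (0.24 log units; within the scatter). The shorter 1-(hydroxymethyl)ethyl substituent stays as far from the 2-aminoethyl as the larger one did, with a 27-fold higher number from compound 1 to compound 4 (1.43 log units; beyond the scatter), against a 16-fold higher number from compound 1 to compound 3 (1.19 log units; beyond the scatter). The remaining step, an at least 1.1-fold lower number from compound 2 to compound 4 (0.06 log units; that floor lies within the scatter), cannot be read, since it starts from a limit and not a number: the limit of > 50000 nM in this assay, at which 1 of the 4 values shown sits.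

Still open, on these data alone, is whether the gap to compound 1 rests on the amine itself. A longer aminoalkyl chain, a tertiary amine or a carboxylic acid on the same amide nitrogen would test this.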